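This account rests on a few compounds, and the source may have more. Where it says the series, first, only, none or still open, it means among the compounds named here.

In an ADME assay on THP-1 cells (Homo sapiens) for inhibition, read by MTT assay, with a stated time of 48 h (a higher number here means a weaker inhibitor of growth, a lower number a stronger inhibitor of growth), three compounds have been measured so far:

Compound 1 `O=[N+]([O-])c1ccc(Cn2cc(COc3ccccc3)nn2)cc1` gives 62.9 ug/mL.
Compound 2 `Clc1ccc(Cn2cc(COc3ccccc3)nn2)cc1` gives 36.4 ug/mL.
Compound 3 `O=[N+]([O-])c1ccc(Cn2cc(COc3ccc(Cl)cc3)nn2)cc1` gives 31.1 ug/mL.

Compounds 1 and 2 share one core and differ in a single spot, (chloro in place of nitro on an aromatic carbon); this change brought a 1.7-fold lower number from compound 1 to compound 2 (0.24 log units; within the scatter), a step that stays within the usual scatter of repeated measurements. Compound 3 carries a second core that differs from the core of compound 1 by chloro in place of hydrogen on an aromatic carbon, and that difference gave a 2.0-fold lower number from compound 1 to compound 3 (0.31 log units; beyond the scatter), a modest step.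

Compound 4 `Clc1ccc(Cn2cc(COc3ccc(Cl)cc3)nn2)cc1` has not been measured yet. It stands to compound 3 as compound 2 stands to compound 1: the difference is chloro in place of nitro on an aromatic carbon, and the place described for it matches word for word the place described for the change from compound 1 to compound 2, so it is the same change on the second core. Among the measured compounds shown here, the only guide to its effect is the one earlier step, which was a 1.7-fold lower number from compound 1 to compound 2 (0.24 log units; within the scatter) and lay within the scatter. For compound 4 the expectation is therefore a step of about a 1.6-fold lower number from compound 3 to compound 4 (0.19 log units; within the scatter), a small shift in the same direction as that earlier step, if the change behaves alike on both cores. On that basis compound 4 is estimated at 20 ug/mL, with a likely range from 10 ug/mL to 40 ug/mL in this assay.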

Compound 4, concentration for 50% growth inhibition: 17.4 ug/mL
Estimate against measurement, compound 4: 1.1-fold (0.06 log units) above; measured number inside the range.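

In this assay, putting chloro in place of nitro on the second core gave a 1.8-fold lower number from compound 3 to compound 4 (0.25 log units; within the scatter), a step that matches the one seen on the first core: the same change on two cores in this assay, a 1.7-fold lower number (0.24 log units; within the scatter) from compound 1 to compound 2 and a 1.8-fold lower number (0.25 log units; within the scatter) from compound 3 to compound 4, 1.0-fold (0.01 log units) apart, within the scatter of two such steps
The other change, chloro in place of hydrogen on an aromatic carbon, gave a 2.1-fold lower number from compound 2 to compound 4 (0.32 log units; beyond the scatter), and it also kept its size when the core changed: the same change on two cores in this assay, a 2.0-fold lower number (0.31 log units; beyond the scatter) from compound 1 to compound 3 and a 2.1-fold lower number (0.32 log units; beyond the scatter) from compound 2 to compound 4, 1.0-fold (0.01 log units) apart, within the scatter of two such steps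
Across these four compounds, each change therefore behaves the same whichever form of the other site is present, but this rests on just one pair of steps per change in a single assay, the nitro-to-chloro steps are each within the scatter and so do not firmly establish an effect on their own, and nothing here explains why the numbers move.

The compounds shown leave open whether other groups at these places, such as an amine, a carboxylic acid or a longer chain, would also carry their effect unchanged from one core to another. They also leave open whether the agreement seen here would hold on a core further removed from these four compounds, or in other cells.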